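The source may hold more compounds than are shown below. What is called first, only, known or untested is meant among the compounds shown, and "the series" means these compounds.

Within the data shown here, in a functional assay on T98G cells (Homo sapiens) for cytotoxicity, read by MTT assay, with a stated time of 48 h (on this read-out higher numbers stand for weaker inhibition and lower numbers for stronger inhibition), two compounds have numbers so far. Compound 1 `CCCCCCCCCC[n+]1cccc(OP(=O)([O-])OC[C@H]2O[C@@H](n3cc(F)c(=O)[nH]c3=O)C[C@@H]2OC(=O)c2ccccc2)c1` gives 400 nM, while compound 2 `O=C(O[C@H]1C[C@H](n2cc(F)c(=O)[nH]c2=O)O[C@@H]1COP(=O)([O-])Oc1ccc[n+](Cc2ccccc2)c1)c1ccccc1` gives 2600 nM, the higher of the two numbers and so the weaker inhibition. Compound 3 `CCOC(=O)C[n+]1cccc(OP(=O)([O-])OC[C@H]2O[C@@H](n3cc(F)c(=O)[nH]c3=O)C[C@@H]2OC(=O)c2ccccc2)c1` has not yet been measured. It differs from compound 2 in one place: ethoxycarbonyl in place of phenyl on a saturated chain carbon bound to an aromatic nitrogen. In words, ethoxycarbonyl stands in place of phenyl on a saturated chain carbon bound to an aromatic nitrogen. Among the measured compounds shown here, only one measured step bears on this place: a 6.5-fold higher number from compound 1 to compound 2 (0.81 log units; beyond the scatter), a modest change beyond the scatter, made on that same carbon. Compound 3 carries no nonyl, and neither does compound 2, so the gain seen with compound 1 at 400 nM offers no reason to expect a lower number. For the measured compounds named here, no measured compound carries ethoxycarbonyl, so the evidence is thin. In this assay a small upward shift is expected, smaller than the measured step and possibly within the scatter. The expected change is a 1.3-fold higher number from compound 2 to compound 3 (0.13 log units; within the scatter). For compound 3 the estimated value is 3500 nM, with an expected range from 1200 nM to 10000 nM.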

Compound 3, half-maximal inhibitory concentration: 1600 nM
For compound 3 the middle estimate is 2.2-fold (0.34 log units) above the measured one; the measured number falls inside the stated range.
By their numbers in this assay, from the lowest: compound 1; then compounds 3 and 2 (each within the scatter of the next).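

In this assay, ethoxycarbonyl in place of phenyl on a saturated chain carbon bound to an aromatic nitrogen gives a 1.6-fold lower number from compound 2 to compound 3 (0.21 log units; within the scatter) and so cannot be told apart from the phenyl compound, which shows that this place tolerates a group with no ring and with hydrogen-bond acceptors as well as it tolerates a ring of carbon only. Ethoxycarbonyl in place of nonyl gives a 4.0-fold higher number from compound 1 to compound 3 (0.60 log units; beyond the scatter) and this lies beyond the scatter, as does a 6.5-fold higher number from compound 1 to compound 2 (0.81 log units; beyond the scatter) on the same carbon, so among these three compounds nonyl alone stands apart, while the other two groups, different as they are, give numbers within the scatter of each other. Nothing offered here accounts for either of these differences.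

The three compounds do not tell whether the lower number of compound 1 belongs to nonyl in particular or would also appear with a shorter or longer chain on that carbon. They also leave open how a carboxylic acid or an amine at this place would read, and whether the ethyl part of the ester has any bearing on the number.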